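Aryl-to-thienyl swap on the oxadiazole of the nitroimidazole series

The source may report more compounds than this note shows. Statements on the series, on what has been measured and on what is new or still open speak of the compounds shown alone.

Compound 1 `Cc1ccc(-c2nnc(SCCn3c([N+](=O)[O-])cnc3C)o2)cc1` gives 12500 nM in a functional assay on SGC-7901 cells (Homo sapiens) for cytotoxicity, read by MTT assay, with a stated time of 48 h (a higher number here means a weaker inhibitor, a lower number a stronger inhibitor), the second highest of the three numbers in hand. Compound 3 `Cc1ncc([N+](=O)[O-])n1CCSc1nnc(-c2ccc([N+](=O)[O-])cc2)o1` gives 12200 nM and compound 2 `CCOc1ccc(-c2nnc(SCCn3c([N+](=O)[O-])cnc3C)o2)cc1` gives 14100 nM; the steps of a 1.0-fold lower number from compound 1 to compound 3 (0.01 log units; within the scatter), a 1.1-fold higher number from compound 1 to compound 2 (0.05 log units; within the scatter) and a 1.2-fold lower number from compound 2 to compound 3 (0.06 log units; within the scatter) all lie within the scatter, so these three values show no separation.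

Compound 4 `Cc1ncc([N+](=O)[O-])n1CCSc1nnc(-c2cccs2)o1` is unmeasured. Its change from compound 1: thiophen-2-yl in place of 4-methylphenyl on an aromatic carbon. Among the measured compounds shown here, no measured step replaces the six-membered ring itself; the three measured steps only exchange a group on that ring, and none moved the number beyond the scatter. Compound 4 is therefore expected near compound 1, with a step of about a 1.0-fold lower number from compound 1 to compound 4 (0.02 log units; within the scatter). The estimate for compound 4 is 12000 nM, in a range from 5000 nM to 30000 nM.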

Compound 4, half-maximal inhibitory concentration: 30800 nM
Compound 4: middle estimate off by 2.6-fold (0.41 log units), on the low side; measured number outside the range, above it.
By their numbers in this assay, from the lowest: compounds 3, 1 and 2 (each within the scatter of the next); then compound 4.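

Replacing the six-membered ring itself moves the number where exchanging methyl, ethoxy and nitro on that ring did not: in this assay thiophen-2-yl in place of 4-methylphenyl gives a 2.5-fold higher number from compound 1 to compound 4 (0.39 log units; beyond the scatter) and so weaker inhibition. Among the compounds shown here, at this aromatic carbon, the ring is the only change so far that separates compounds beyond the scatter. No measurement in hand accounts for this step.

Open, on these data alone, is whether plain phenyl stays with compound 1, which would separate the ring change from the loss of methyl. Also open, as far as these compounds go, is whether furan-2-yl or pyridin-3-yl here follows compound 4 or compound 1.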